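From Methyl to Sec-Butyl on the Chain Carbon

The source may report more compounds than this note shows. Statements on the series, on what has been measured and on what is new or still open speak of the compounds shown alone.

In a functional assay on HeLa cells (Homo sapiens) for antiproliferative activity, read by MTT assay, with a stated time of 48 h (on this read-out lower numbers stand for stronger inhibition and higher numbers for weaker inhibition), compound 1 `COC(=O)CNC(=O)c1ccc(Oc2nc3ccccc3nc2NC(C)(C)C)cc1` gives > 50000 nM, which is a limit of the assay. Compound 2 `CC(C)(C)Nc1nc2ccccc2nc1Oc1ccc(C(=O)NCC(=O)O)cc1` gives > 50000 nM, also a limit. This leaves a step that the two limits leave unreadable from compound 1 to compound 2. Going by the values given here, compound 3 `C[C@H](NC(=O)c1ccc(Oc2nc3ccccc3nc2NC(C)(C)C)cc1)C(=O)O` gives 23400 nM, the only actual number so far.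

Compound 4 `CC[C@@H](C)[C@H](NC(=O)c1ccc(Oc2nc3ccccc3nc2NC(C)(C)C)cc1)C(=O)O` has sec-butyl in place of methyl on a saturated chain carbon bound to an amide-type nitrogen and a carbonyl carbon, a difference of sec-butyl in place of methyl on a saturated chain carbon bound to an amide-type nitrogen and a carbonyl carbon.

Among the compounds with values here, the closest precedent at this carbon is an at least 2.1-fold lower number from compound 2 to compound 3 (0.32 log units; beyond the scatter), where methyl replaces hydrogen. The other step ending at compound 3 is an at least 2.1-fold lower number from compound 1 to compound 3 (0.32 log units; beyond the scatter), where 1-carboxyethyl replaces (methoxycarbonyl)methyl. Both sizes are only lower bounds, and they share the same end point, so the trend rests on very little. A modest further drop in this assay is expected, but a change within the scatter would not be surprising.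

The estimated change is a 1.7-fold lower number from compound 3 to compound 4 (0.22 log units; within the scatter). For compound 4, the expected value is 14000 nM, with an estimated range of 4000 nM to 45000 nM.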

Compound 4, half-maximal inhibitory concentration: 13400 nM
Estimate against measurement, compound 4: 1.0-fold (0.02 log units) above, within the range that was stated.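

In this assay, the move from methyl to sec-butyl on the saturated chain carbon bound to an amide-type nitrogen and a carbonyl carbon gives a 1.7-fold lower number from compound 3 to compound 4 (0.24 log units; within the scatter), so the larger group does not separate compound 4 from compound 3. Going by these compounds alone, measured against the compounds without a group at this carbon or with the ester side chain, sec-butyl gives a clearer margin than the earlier compounds could show, with an at least 3.7-fold lower number from compound 2 to compound 4 (0.57 log units; beyond the scatter) and an at least 3.7-fold lower number from compound 1 to compound 4 (0.57 log units; beyond the scatter). Both of these sizes are only lower bounds, and their true extent cannot be read: the limit of > 50000 nM in this assay, at which 2 of the 4 values shown sit.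

The compounds shown leave open whether a phenyl or hydroxymethyl group at this carbon would keep the margin seen with methyl and sec-butyl. As far as these compounds go, it also remains open how a methyl ester in place of the carboxylic acid of compound 4 would read.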